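Swapping the aryl group on a shared core

A few compounds are considered here, and "the series" means these few. Any claim that something is new, unique, unknown or untested is made for them only; others in the source may bear on it.

Measured compounds:
compound 1 `COc1cc(-c2ccnc3cc(-c4ccc(C(F)(F)F)cc4)nn23)cc(OC)c1OC` – 1770 nM
compound 2 `COc1cc(-c2ccnc3cc(-c4cccc5c4ccn5CO)nn23)cc(OC)c1OC` – 1090 nM
compound 3 `CCOC(=O)c1ccc(-c2cc3nccc(-c4cc(OC)c(OC)c(OC)c4)n3n2)cc1` – a limit, > 10000 nM

All three compounds share one core and differ only in the aryl group attached to it. In a functional assay on B16-F0 cells (Mus musculus) for inhibition, read by CCK-8 assay, with a stated time of 48 h (on this read-out lower numbers stand for stronger inhibition and higher numbers for weaker inhibition), compound 1 gives 1770 nM. Compound 2 gives 1090 nM, which lies within the scatter of the number for compound 1. Compound 3 reaches only the limit of this assay (the limit of > 10000 nM in this assay, at which 1 of the 3 values shown sits), so it is a limit and not a number. Going by the values given here, the one step measured at this position is an at least 5.6-fold higher number from compound 1 to compound 3 (0.75 log units; beyond the scatter), showing that changing this aryl group can weaken inhibition markedly.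

Compound 4 `COc1ccc(-c2cc3nccc(-c4cc(OC)c(OC)c(OC)c4)n3n2)cc1N` is not yet measured. It differs from compound 1 by 3-amino-4-methoxyphenyl in place of 4-(trifluoromethyl)phenyl on an aromatic carbon. Among the compounds with values here, no measured step covers an amino or methoxy group at this place; the step to compound 3 points to weaker inhibition, while compound 2 shows another aryl group leaving the number unchanged within the scatter. A step of a 1.0-fold higher number from compound 1 to compound 4 (0.01 log units; within the scatter) is therefore expected, small and uncertain in direction. Compound 4 is estimated at 1800 nM, within 450 nM to 8000 nM.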

Compound 4, half-maximal inhibitory concentration: 88 nM
Beside the measured number, compound 4's estimate is 20-fold (1.31 log units) above it, outside the stated range (below it).
By their numbers in this assay, from the lowest: compound 4; then compounds 2 and 1 (each within the scatter of the next). At a limit, above all of these: compound 3.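

Putting 3-amino-4-methoxyphenyl in place of 4-(trifluoromethyl)phenyl gives a 20-fold lower number from compound 1 to compound 4 (1.30 log units; beyond the scatter) in this assay. The earlier compounds shown here showed only a loss of inhibition or a number within the scatter, whereas this step shows that a change at this aromatic carbon can also strengthen inhibition by a large margin. The whole aryl group changes in this step, bringing in an amino group and a methoxy group together, and the information given here offers no explanation for the drop in the number.

Which of the two groups matters most remains open, and a phenyl group carrying only the amino group or only the methoxy group could separate them. An acetamide or a hydroxyl group in place of the amino group could show whether the amino group itself is needed.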